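Cyclopropyl-oxazole sulfonamides: methoxy to methyl on the fused ring

The compounds below may be only part of what the source reports. "The series", "measured", "known", "first", "only" and "open" are said of these compounds alone.

Measured so far:
compound 1 `O=[N+]([O-])c1ccc2c(c1)N(S(=O)(=O)c1ccc(-c3cnc(C4CC4)o3)cc1)CCCO2` — 133 nM
compound 2 `COc1ccc2c(c1)N(S(=O)(=O)c1ccc(-c3cnc(C4CC4)o3)cc1)CCCO2` — 47 nM

Compound 2 stands lowest of the two numbers in a functional assay on HCT-116 cells (Homo sapiens) for antiproliferative activity, read by MTT assay, with a stated time of 72 h; a higher number here means a weaker inhibitor, a lower number a stronger inhibitor; its nearest neighbour is compound 1, and the step of a 2.8-fold lower number from compound 1 to compound 2 (0.45 log units; beyond the scatter) lies beyond the scatter. Compound 3 `Cc1ccc2c(c1)N(S(=O)(=O)c1ccc(-c3cnc(C4CC4)o3)cc1)CCCO2` differs from compound 2 in one place: methyl in place of methoxy on an aromatic carbon. Among the measured compounds shown here, no measured step swaps methoxy for methyl, so only the step from compound 1 to compound 2 bears on it, and only loosely. The expectation is therefore a step of a 1.3-fold higher number from compound 2 to compound 3 (0.11 log units; within the scatter) that stays within the scatter. Compound 3 is estimated at 60 nM, with a range from 25 nM to 150 nM.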

Compound 3, half-maximal inhibitory concentration: 29 nM
Beside the measured number, compound 3's estimate is 2.1-fold (0.32 log units) above it; low and high end bracket the measured number.
By their numbers in this assay, from the lowest: compounds 3 and 2 (each within the scatter of the next); then compound 1.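

Methyl in place of methoxy on this aromatic carbon gives in this assay a 1.6-fold lower number from compound 2 to compound 3 (0.21 log units; within the scatter) and so does not separate the two groups, although the hydrogen-bond acceptor of the methoxy is gone. Methyl in place of nitro gives a 4.6-fold lower number from compound 1 to compound 3 (0.66 log units; beyond the scatter) and shows that compound 1 stands apart from compound 3 as well as from compound 2. No measurement on hand accounts for these steps.

Open, on these data alone, is whether an amine, a chlorine or a longer alkyl chain at this position stays in the range of compound 2 and compound 3. Also open, as far as these compounds go, is whether methyl and methoxy match elsewhere on the core.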